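Adding a Sulfonamide Arm to a Non-Toxic Lactam Scaffold

A few compounds are considered here, and "the series" means these few. Any claim that something is new, unique, unknown or untested is made for them only; others in the source may bear on it.

This piece follows one change made to compound 1, whose structure is `COc1ccc([C@H]2CC(=O)N(c3ccccc3)C2)cc1OC1CCCC1`. In a functional assay on HEK293 cells (Homo sapiens) for cytotoxicity (a lower number here means that less compound is tolerated, a higher number that more compound is tolerated), compound 1 gives > 10000 nM, and this is a limit of the assay rather than a number. A related compound 2, with structure `COc1ccc([C@H]2CC(=O)N(c3ccncc3)C2)cc1OC1CCCC1`, carries a pyridin-4-yl in place of phenyl on an amide-type nitrogen in a ring. In this assay compound 2 gives > 10000 nM, again a limit rather than a number. The step that the two limits leave unreadable from compound 1 to compound 2 therefore cannot be read, which rests on (the limit of > 10000 nM in this assay, at which 2 of the 2 values shown sit).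

The compound not yet measured is compound 3, with structure `COc1ccc([C@H]2CC(=O)N(c3cccc(NS(=O)(=O)c4ccccc4Br)c3)C2)cc1OC1CCCC1`. It differs from compound 1 by ((2-bromophenyl)sulfonyl)amino in place of hydrogen on an aromatic carbon. Among the compounds with values here, no measured step bears directly on this change, and the one step available is itself unreadable. The two measured compounds both sit at the limit, so compound 3 is expected to fall near or at that same limit, with the step that the limit leaves unreadable from compound 1 to compound 3 expected to be within the usual scatter. Compound 3 is estimated to give 15000 nM in this assay, within a range of 4000 nM to 50000 nM.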

Compound 3, half-maximal cytotoxic concentration: > 10000 nM
Compound 3 was reported as a limit (the forecaster's own chance of this, stated with the estimate: 65%); the middle value lies beyond the limit too.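

The step between compound 1 and compound 3 cannot be read, because both are reported only as limits, not numbers: the limit of > 10000 nM in this assay, at which 3 of the 3 values shown sit.

The compounds shown leave open whether ((2-bromophenyl)sulfonyl)amino in place of hydrogen changes the result in this assay at all, and which change to the shared core, if any, would give a readable number there.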